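A few compounds are considered here, and "the series" means these few. Any claim that something is new, unique, unknown or untested is made for them only; others in the source may bear on it.

Working notes on a small set of benzamide-type compounds that share an aminophenyl amide and a sulfur-linked side arm. Three have been tested so far in a functional assay on SMMC-7721 cells (Homo sapiens) for inhibition, read by CCK-8 assay, with a stated time of 72 h, tested at 8 uM; on this read-out lower numbers stand for less inhibition of growth and higher numbers for more inhibition of growth at the one concentration tested. Compound 1, `Cc1ccc(SCc2ccc(/C=C/C(=O)Nc3ccccc3N)cc2)cc1`, gives 22.2% in this assay. Compound 2, `Nc1ccccc1NC(=O)c1ccc(CSc2nccc(C(F)(F)F)n2)cc1`, gives 80.6% in this assay. Compound 3, `Nc1ccccc1NC(=O)c1ccc(CSc2ccc(Br)cc2)cc1`, gives 25.3% in this assay.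

Within these three numbers compound 3 stands second highest. Its nearest neighbour is compound 1, whose number lies slightly lower but within the usual scatter, so no order between compound 3 and compound 1 can be read from these two values. The furthest is compound 2, whose number lies well beyond the scatter above that of compound 3.

The next compound, compound 4, `Nc1ccccc1NC(=O)c1ccc(CSc2cccc(F)c2)cc1`, has not yet been measured in this assay. Its structure differs from compound 3 in one place: 3-fluorophenyl in place of 4-bromophenyl on a sulfur. Within the data shown here, no measured pair shows this kind of exchange, so no step size can be taken from the data. The expectation is a step from compound 3 to compound 4 of a number 2.7 percentage points higher from compound 3 to compound 4 (within the scatter) in this assay, which is no change beyond the scatter. Compound 4 is accordingly estimated at 28% in this assay, with a range from 12% to 48%.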

Compound 4, percent growth inhibition at one concentration: 83%
Beside the measured number, compound 4's estimate is 55 percentage points below it; the measured number lies above the stated range.
By their numbers in this assay, from the lowest: compounds 1 and 3 (each within the scatter of the next); then compounds 2 and 4 (each within the scatter of the next).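

In this assay, the exchange of 4-bromophenyl for 3-fluorophenyl on a sulfur gives a number 57.7 percentage points higher from compound 3 to compound 4 (beyond the scatter), which shows that the read-out at the one concentration tested can depend strongly on the aryl group at this place. The step arises with the shared core and the sulfur link unchanged, and with the counts computed for the two groups matching: each has the same number of heavy atoms, one six-membered aromatic ring of carbon only, no hydrogen-bond donors or acceptors, and no net charge. These matching counts therefore do not separate the two groups, and no measurement at hand explains the size of the step.

The exchange alters both the halogen and its numbered place on the phenyl ring, and no compound shown holds one fixed while the other changes, so the two contributions to the step remain unresolved. Also open, as far as these compounds go, is how the series responds when the phenyl ring on the sulfur carries an amine or a carboxylic acid in place of a halogen.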